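Methoxy in place of hydroxy on the chain carbon

The source may report more compounds than this note shows. Statements on the series, on what has been measured and on what is new or still open speak of the compounds shown alone.

Compound 1 `CO/N=C(\CCN1CCN(c2ccccn2)CC1)c1ccccc1Cl`: 42.3 nM in a functional assay on HEK293 cells with D(4) dopamine receptor (Homo sapiens) as the target, read by FLIPR; on this read-out higher numbers stand for an effect only at larger amounts of compound and lower numbers for an effect already at smaller amounts
Compound 2 `Cc1cccc(/C(=N\O)C(O)CN2CCN(c3ccccn3)CC2)c1`: 44.8 nM in this assay
Compound 3 `Cc1cccc(/C(=N/O)C(O)CN2CCN(c3ccccn3)CC2)c1`: 4.9 nM in this assay

Among these three, compound 3 gives the lowest number in this assay; the nearest is compound 1, and the largest gap is to compound 2. Among the measured compounds shown here, the single measured step, a 9.1-fold lower number from compound 2 to compound 3 (0.96 log units; beyond the scatter), goes with a change of drawn double-bond geometry alone, a point already noted in the fact that one of compounds 2 and 3 is drawn with a defined configuration and the other without, at the place where they differ.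

Compound 4 `COC(CN1CCN(c2ccccn2)CC1)/C(=N\O)c1cccc(C)c1` differs from compound 3 by methyl in place of hydrogen on an oxygen on a saturated carbon, so that the hydroxy becomes a methoxy. For the measured compounds named here, no measured pair shows this change: the step from compound 2 to compound 3 concerns the oxime geometry and not the oxygen on the chain carbon, and compound 1 carries its methyl on a different oxygen. With nothing measured that bears on it, the step in this assay is expected to lie within the scatter or only slightly beyond, with no direction favoured. Compound 4 is therefore expected at 8 nM, within 2.5 nM to 40 nM, which means an expected step of a 1.6-fold higher number from compound 3 to compound 4 (0.21 log units; within the scatter).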

Compound 4, half-maximal effective concentration: 34.5 nM
Compound 4: middle estimate off by 4.3-fold (0.63 log units), on the low side; the range from low to high includes it.
By their numbers in this assay, from the lowest: compound 3; then compounds 4, 1 and 2 (each within the scatter of the next).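

In this assay, turning the hydroxy on the saturated chain carbon into a methoxy is not a neutral change, as the step shows: a 7.0-fold higher number from compound 3 to compound 4 (0.85 log units; beyond the scatter). Among the compounds shown here, this is the first measured change at this oxygen, and it shows that the low number of compound 3 does not depend on the oxime geometry alone, since it is also lost when methyl replaces the hydrogen on this oxygen. Nothing at hand gives a reason for this step.

From the compounds shown here alone, it remains open whether an ethoxy or an amine on the same chain carbon would read like the hydroxy of compound 3 or like the methoxy of compound 4. Also open, going by these compounds, is whether the same change would shift the number similarly with the oxime geometry of compound 2.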